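The source may hold more compounds than are shown below. What is called first, only, known or untested is meant among the compounds shown, and "the series" means these compounds.

Measured so far in an assay on cells for inhibition of cytochrome P450 11B1, mitochondrial (Homo sapiens); on this read-out higher numbers stand for weaker inhibition and lower numbers for stronger inhibition:
compound 1, `CC(C)CC1n2cncc2CN(CC2CC2)S1(=O)=O`: 122 nM
compound 2, `CC(C)CC1n2cncc2CN(C2CC2)S1(=O)=O`: 930 nM
compound 3, `CC(C)OCC1n2cncc2CN([C@@H](C)c2ccc(Cl)cc2)S1(=O)=O`: 222 nM

Among these three numbers compound 3 stands second highest. Its value lies close to that of compound 1, a gap within the usual scatter, whereas compound 2 sits well apart from it, beyond the scatter. Compound 4, `CC(C)CC1n2cncc2CN([C@@H](C)c2ccc(Cl)cc2)S1(=O)=O`, arises from compound 3 by one change: isopropyl in place of isopropoxy on a saturated chain carbon bound to a saturated ring carbon. Among the measured compounds shown here, the only step measured so far, a 7.6-fold higher number from compound 1 to compound 2 (0.88 log units; beyond the scatter), concerns the substituent on the sulfonamide nitrogen in the ring and leaves the chain untouched, so it says nothing direct about this change. Compound 1 and compound 3 differ in two places at once, on the chain and on that nitrogen, so their two values, near each other, give only an indirect hint that the chain substituent may matter little. For the measured compounds named here, with no measured step bearing on the change itself, the expected step from compound 3 to compound 4 is none beyond the scatter: a 1.1-fold lower number from compound 3 to compound 4 (0.05 log units; within the scatter). Compound 4 is therefore estimated at 200 nM in this assay, within a range of 70 nM to 600 nM.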

Compound 4, half-maximal inhibitory concentration: 76 nM
For compound 4 the middle estimate is 2.6-fold (0.42 log units) above the measured one; low and high end bracket the measured number.
By their numbers in this assay, from the lowest: compounds 4, 1 and 3 (each within the scatter of the next, the first and the last beyond it); then compound 2.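

In this assay, among the compounds shown here, the first measured change on this chain is a real one: isopropyl in place of isopropoxy on a saturated chain carbon bound to a saturated ring carbon gives a 2.9-fold lower number from compound 3 to compound 4 (0.47 log units; beyond the scatter) and so this position does respond to its substituent. The step is modest, and compound 4 has the lower number, so in this one pair the isopropoxy group, which brings an oxygen and a hydrogen-bond acceptor that the isopropyl group lacks, gives the weaker inhibition. Nothing in the available data accounts for this difference.

Going by these compounds, the two groups are compared only with the substituent that compound 3 and compound 4 share on the sulfonamide nitrogen in the ring, so whether the step carries over to a cyclopropylmethyl or cyclopropyl group on that nitrogen stays open. Also open, on these data alone, is what a methoxy group, a hydroxyl, an amine or a longer chain such as pentyl would give at this place, and whether the oxygen itself or the size of the group sets the number.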